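The source may hold more compounds than are shown below. What is called first, only, known or untested is meant among the compounds shown, and "the series" means these compounds.

Measured in a physicochemical assay for lipophilicity, at pH 7.4; a lower number here means a more polar compound, a higher number a more lipophilic compound:
- compound 1 `CNC(=O)c1cc(C(=O)N[C@H]2CC[C@H](O)CC2)cc2c1OC[C@@]2(C)c1ccccc1`: 3.3
- compound 2 `CNC(=O)c1cc(C(=O)NCCC[C@H]2OC[C@H](N)CO2)cc2c1OC[C@H]2c1ccccc1`: 2.6

Compound 1 stands highest of the two, and compound 2 lies lower, beyond the scatter.

Compound 3 `CNC(=O)c1cc(C(=O)N[C@H]2[C@@H]3C[C@@H](O)C[C@@H]32)cc2c1OC[C@@]2(C)c1ccccc1` differs from compound 1 on an amide-type nitrogen: a group of 7 heavy atoms (6 carbon, 1 oxygen; one three-membered non-aromatic ring of carbon only, one five-membered non-aromatic ring of carbon only) in place of a group of 7 heavy atoms (6 carbon, 1 oxygen; one six-membered non-aromatic ring of carbon only), on an amide-type nitrogen. For the measured compounds named here, no measured step between compounds that differ in one place is available, so the expectation rests on the structural change alone. The heavy atoms are matched in number and kind, and no step beyond the scatter is expected in this assay. The expected change is a number 0.10 log units lower from compound 1 to compound 3 (within the scatter). Compound 3 is estimated at 3.2, with an expected range from 2.8 to 3.6.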

Compound 3, distribution coefficient: 3.3
Compound 3: middle estimate off by 0.10 log units, on the low side; the range from low to high includes it.
By their numbers in this assay, from the lowest: compound 2; then compounds 1 and 3 (each within the scatter of the next).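

At the amide-type nitrogen, placing the group with one three-membered and one five-membered non-aromatic ring of carbon only where 4-hydroxycyclohexyl stood gives (no change at the digits printed from compound 1 to compound 3 (within the scatter)) in this assay. For the compounds shown here, this is the first one-place step, and it shows that this ring change, with heavy atoms and hydrogen-bond counts matched, leaves the number within the scatter on the core of compound 1. No measurement shown offers an explanation for this result.

From the compounds shown here alone, whether an amine or a carboxylic acid in place of the hydroxyl on this ring group would shift the number remains open. So does whether the step holds on another core.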